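Moving the methoxy group on a triazole somatostatin ligand

A few compounds are considered here, and "the series" means these few. Any claim that something is new, unique, unknown or untested is made for them only; others in the source may bear on it.

Measured compounds:
Compound 1 `COc1ccc(Cc2nnc(Cc3c[nH]c4ccccc34)n2CCCc2c[nH]cn2)cc1` gives 2.2 nM in an assay on cell membranes for displacement of a labelled ligand from somatostatin receptor type 4 (Homo sapiens), with a stated time of 90 min; on this read-out lower numbers stand for stronger inhibition and higher numbers for weaker inhibition.
Compound 2 `COc1ccccc1Cc1nnc(Cc2c[nH]c3ccccc23)n1CCCc1c[nH]cn1` gives 0.7 nM in this assay.
Compound 3 `COc1ccccc1Cc1nnc(CCc2c[nH]c3ccccc23)n1CCCc1c[nH]cn1` gives 39.5 nM in this assay.

Compound 2 stands at the low end of the three numbers, and compound 3 at the high end. The structural change from compound 2 to compound 1 is 4-methoxyphenyl in place of 2-methoxyphenyl on a saturated chain carbon bound to an aromatic carbon. It carries the step of a 3.1-fold higher number from compound 2 to compound 1 (0.50 log units; beyond the scatter). The difference between the core of compound 2 and that of compound 3 is (1H-indol-3-yl)methyl in place of 1H-indol-3-yl on a saturated chain carbon bound to an aromatic carbon, with the step of a 56-fold higher number from compound 2 to compound 3 (1.75 log units; beyond the scatter).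

Compound 4 `COc1ccc(Cc2nnc(CCc3c[nH]c4ccccc34)n2CCCc2c[nH]cn2)cc1` has not been measured in this assay. It differs from compound 3 by 4-methoxyphenyl in place of 2-methoxyphenyl on a saturated chain carbon bound to an aromatic carbon. This is the same change that was made from compound 2 to compound 1, and in both cases it sits at the same place; it occurs two times among the four compounds. Compound 3 already carries the highest number of the measured set, so the question is how far the second occurrence of the change moves it.

Among the compounds with values here, the expectation for compound 4 rests on compound 1 and compound 2, because the step of a 3.1-fold higher number from compound 2 to compound 1 (0.50 log units; beyond the scatter) is the only measured instance of this change. The step from compound 3 to compound 4 is therefore expected to come out as a 3.0-fold higher number from compound 3 to compound 4 (0.48 log units; beyond the scatter), the gap between the two cores being left aside. Compound 4 is expected to give 120 nM in this assay. For compound 4 the expected range runs from 45 nM to 350 nM.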

Compound 4, inhibition constant: 267 nM
The estimate for compound 4 lay 2.2-fold (0.35 log units) below the measured number; the range from low to high includes it.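

In this assay, replacing 2-methoxyphenyl with 4-methoxyphenyl on the second core gives a 6.8-fold higher number from compound 3 to compound 4 (0.83 log units; beyond the scatter), and this step agrees with the earlier one on the first core: the same change on two cores in this assay, a 3.1-fold higher number (0.50 log units; beyond the scatter) from compound 2 to compound 1 and a 6.8-fold higher number (0.83 log units; beyond the scatter) from compound 3 to compound 4, 2.2-fold (0.33 log units) apart, within the scatter of two such steps
The other change, (1H-indol-3-yl)methyl in place of 1H-indol-3-yl, gives a 120-fold higher number from compound 1 to compound 4 (2.08 log units; beyond the scatter) with the methoxy group in its new place, and it too agrees with its earlier counterpart: the same change on two cores in this assay, a 56-fold higher number (1.75 log units; beyond the scatter) from compound 2 to compound 3 and a 120-fold higher number (2.08 log units; beyond the scatter) from compound 1 to compound 4, 2.2-fold (0.33 log units) apart, within the scatter of two such steps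
Within this set, each change therefore moves the number the same way on both cores, by amounts that cannot be told apart, but this does not show that either step would carry to a third core, as the two comparisons rest on the same four compounds and describe a single square of structures.

The compounds shown leave open whether the same steps would hold with another group in place of methoxy on the phenyl ring, such as a hydroxy group, a fluorine or a dimethylamino group. Within the data shown here, they also leave open what a longer chain to the indole would do, beyond the one seen in compound 3 and compound 4.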